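This account rests on a few compounds, and the source may have more. Where it says the series, first, only, none or still open, it means among the compounds named here.

For the measured compounds named here, in a functional assay on Ehrlich cells (Mus musculus) for cytotoxicity, tested at 100 ug/mL (on this read-out lower numbers stand for a weaker effect and higher numbers for a stronger effect at the one concentration tested), compound 1 `COc1cc(N2C(N)=C(C#N)C(c3c(O)ccc4ccccc34)C3=C2CC(C)(C)CC3=O)cc(OC)c1OC` gives 90% and compound 2 `COc1cc(N2C(N)=C(C#N)C(c3ccccc3O)C3=C2CC(C)(C)CC3=O)cc(OC)c1OC` gives 10%, so compound 2 stands lowest of the two numbers, the only recorded step being a number 80 percentage points lower from compound 1 to compound 2 (beyond the scatter). Compound 3 `COc1cc(N2C(N)=C(C#N)C(c3ccccc3)C3=C2CC(C)(C)CC3=O)cc(OC)c1OC` differs from compound 2 by hydrogen in place of hydroxy on an aromatic carbon. Going by the values given here, no measured step bears on this particular change; the one step recorded concerns a different part of the molecule. A step of a number 5 percentage points higher from compound 2 to compound 3 (within the scatter) is therefore expected, a movement not beyond the scatter. Compound 3 is estimated at 15%, with a range from 0% to 45%.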

Compound 3, a percentage reported as activity, at one concentration (the size of the read-out at that concentration, not a potency): 10%
Compound 3: middle estimate off by 5 percentage points, on the high side, and the stated range covers the measured number.
By their numbers in this assay, from the lowest: compounds 2 and 3 (each within the scatter of the next); then compound 1.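

In this assay the change from 2-hydroxyphenyl to phenyl gives no change at the digits printed from compound 2 to compound 3 (within the scatter) and shows that this hydroxy on the aromatic carbon does not by itself separate the two compounds. Phenyl likewise gives a number 80 percentage points lower from compound 1 to compound 3 (beyond the scatter) and so leaves the large gap to 2-hydroxynaphthalen-1-yl in place with or without that hydroxy. Nothing available explains either result. Open, as far as these compounds go, is whether an amine or a methoxy in place of that hydroxy would read differently. Also open, from the compounds shown here alone, is whether naphthalen-1-yl without its hydroxy would keep the high reading of compound 1.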